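Compound 1 to compound 4: dichlorophenyl isomers

This account rests on a few compounds, and the source may have more. Where it says the series, first, only, none or still open, it means among the compounds named here.

In a functional assay on THP-1 cells (Homo sapiens), read by colorimetric assay, with stated times of 1 h and 1.5 h (on this read-out lower numbers stand for an effect already at smaller amounts and higher numbers for an effect only at larger amounts of compound), compound 1 `C=C(C(=O)OCC)C(OCCC(=O)OCC)c1ccc(Cl)cc1Cl` gives 200 nM. Compound 2 `C/C=C(/C(=O)OCC)C(O)c1ccccc1Cl` gives 158 nM, within the scatter of compound 1. Compound 3 `C/C=C(\C(=O)OCC)C(O)c1ccccc1Cl` gives 501 nM, the highest number of the three and beyond the scatter of compound 1.

Compound 4 `C=C(C(=O)OCC)C(OCCC(=O)OCC)c1c(Cl)cccc1Cl` is not yet measured. It carries 2,6-dichlorophenyl in place of 2,4-dichlorophenyl on a saturated chain carbon bound to a double-bonded chain carbon and an oxygen on a saturated carbon.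

Within the data shown here, the only measured step, a 3.2-fold higher number from compound 2 to compound 3 (0.50 log units; beyond the scatter), concerns double-bond geometry rather than the dichlorophenyl group, so it bears only indirectly. It suggests modest sensitivity to an isomeric change, and no step beyond the scatter is expected in this assay, in either direction.

The expected result is a 1.3-fold higher number from compound 1 to compound 4 (0.10 log units; within the scatter). For compound 4 the estimated value is 250 nM, with an expected range of 70 nM to 800 nM.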

Compound 4, half-maximal effective concentration: 126 nM
For compound 4 the middle estimate is 2.0-fold (0.30 log units) above the measured one; measured number inside the range.
By their numbers in this assay, from the lowest: compounds 4, 2 and 1 (each within the scatter of the next); then compound 3.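

In this assay, among these compounds, 2,6-dichlorophenyl in place of 2,4-dichlorophenyl gives a 1.6-fold lower number from compound 1 to compound 4 (0.20 log units; within the scatter), the first reading of a change at this place on a saturated chain carbon. This rearrangement of the two chlorines leaves the number within the scatter, so the assay separates neither dichlorophenyl isomer from the other. No available evidence bears on this change.

Still open, as far as these compounds go, is how an unsubstituted phenyl group would read at this place. Also open, from the compounds shown here alone, is whether a carboxylic acid in place of the terminal ethyl ester of the side chain would keep the number.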